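The source may hold more compounds than are shown below. What is called first, only, known or untested is meant among the compounds shown, and "the series" means these compounds.

In an ADME assay on the whole organism (Mus musculus, strain CD-1) for pharmacokinetics (on this read-out higher numbers stand for fast clearance and lower numbers for slow clearance), compound 1 (`CCOc1cc([C@](O)(CCN(C)C)[C@@H](c2cc3cc(Br)ccc3nc2OC)c2ccnc(OC)c2OC)cc(OC)n1`) gives 9.5 mL/min/kg, compound 2 (`COc1cc([C@](O)(CCN(C)C)[C@@H](c2cc3cc(Br)ccc3nc2OC)c2ccnc(OC)c2OC)cc(OC(C)C)n1`) gives 6.8 mL/min/kg and compound 3 (`COc1cc([C@](O)(CCN(C)C)[C@@H](c2cc3cc(Br)ccc3nc2OC)c2ccnc(OC)c2OC)cc(OC2CCC2)n1`) gives 11 mL/min/kg. Compound 3 therefore stands level with the other two, within the usual scatter of both. The next compound, compound 4 (`COc1cc([C@](O)(CCN(C)C)[C@@H](c2cc3cc(Br)ccc3nc2OC)c2ccnc(OC)c2OC)cc(OC(F)F)n1`), keeps the same core and alters one group: difluoromethyl in place of cyclobutyl on an oxygen on an aromatic ring. In words, this is difluoromethyl in place of cyclobutyl on an oxygen on an aromatic ring.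

The measured steps that bear on this change all concern the group on that kind of oxygen. They are a 1.4-fold lower number from compound 1 to compound 2 (0.15 log units; within the scatter), a 1.2-fold higher number from compound 1 to compound 3 (0.06 log units; within the scatter) and a 1.6-fold higher number from compound 2 to compound 3 (0.21 log units; within the scatter). None of the three goes beyond the scatter, even though the group varies from a short chain to a ring. Going by the values given here, they offer only a loose guide, however, as no measured compound carries difluoromethyl or any other fluorine on that oxygen. Among the compounds with values here, with those small steps as the only evidence, no shift beyond the scatter is expected in this assay, and the estimated step is a 1.2-fold lower number from compound 3 to compound 4 (0.09 log units; within the scatter). For compound 4, the expected clearance is 9 mL/min/kg, with an estimated range from 4.5 mL/min/kg to 18 mL/min/kg.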

Compound 4, clearance: 8.7 mL/min/kg
Beside the measured number, compound 4's estimate is 1.0-fold (0.01 log units) above it; the range from low to high includes it.
By their numbers in this assay, from the lowest: compounds 2, 4, 1 and 3 (each within the scatter of the next).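

Difluoromethyl brings the first fluorine onto this oxygen on an aromatic ring, yet in this assay all three new steps stay within the scatter (they are a 1.3-fold lower number from compound 3 to compound 4 (0.10 log units; within the scatter); a 1.3-fold higher number from compound 2 to compound 4 (0.11 log units; within the scatter); and a 1.1-fold lower number from compound 1 to compound 4 (0.04 log units; within the scatter)). Going by these compounds alone, the range of groups tolerated at this place is therefore wider than the earlier compounds could show: compounds 1, 2, 3 and 4 carry ethyl, isopropyl, cyclobutyl and difluoromethyl on this oxygen, and no pair among them differs beyond the scatter, so none of the four goes against this pattern. Even the swap from a four-membered ring of carbon only to a group with no ring and with fluorine leaves clearance where it was, so within these compounds the read-out does not separate carbon-only groups from this fluorine-bearing one.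

From the compounds shown here alone, it remains open whether a longer chain, or a chain ending in an amine or a carboxylic acid, on this oxygen would also stay within the scatter. Nothing shown here explains why these four groups give such similar clearance.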